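This account rests on a few compounds, and the source may have more. Where it says the series, first, only, none or still open, it means among the compounds named here.

Measured compounds:
compound 1, `Cc1ccc(-c2c(S(=O)(=O)c3ccccc3)cnc3cc(C)nn23)cc1`, 25.2%
compound 2, `Cc1cc2ncc(S(=O)(=O)c3ccccc3)c(-c3ccc(Br)cc3)n2n1`, 5.2%
compound 3, `Cc1ccc(-c2c(S(=O)(=O)c3ccccc3)cnc3cc(-c4ccc(Br)cc4)nn23)cc1`, 72.6%

Notes on the series. Three compounds have been run in a functional assay on the whole organism for inhibition, with Mus musculus as the target, with a stated time of 2 h, at a dose of 50 mg/kg by the oral route; on this read-out lower numbers stand for less inhibition and higher numbers for more inhibition at the one dose given (going by the name of the read-out). Compound 2 gives 5.2%, compound 1 gives 25.2% and compound 3 gives 72.6% in this assay. The step of a number 20 percentage points higher from compound 2 to compound 1 (beyond the scatter) accompanies the change (methyl in place of bromo on an aromatic carbon). The step of a number 47.4 percentage points higher from compound 1 to compound 3 (beyond the scatter) accompanies the exchange of methyl for 4-bromophenyl on an aromatic carbon. Compound 3 stands highest of the three in this assay, with both of its steps to the other two beyond the scatter. The difference between the core of compound 2 and the core of compound 3 is not broken down here.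

Compound 4, `Cc1ccc(-c2cc3ncc(S(=O)(=O)c4ccccc4)c(-c4ccc(C)cc4)n3n2)cc1`, has not yet been measured in this assay. It differs from compound 3 by methyl in place of bromo on an aromatic carbon. This is the same change as that made from compound 2 to compound 1, at a place described in the same words, and that earlier step was a number 20 percentage points higher from compound 2 to compound 1 (beyond the scatter). Because a number 20 percentage points higher from compound 2 to compound 1 (beyond the scatter) went upward, and because compound 3 already gives 72.6%, the step for compound 4 is expected to be upward but smaller: the expected step is a number 11.4 percentage points higher from compound 3 to compound 4 (beyond the scatter). Compound 4 is thus estimated at 84% in this assay, with a range from 66% to 97%. This rests on a single earlier occurrence of the change, between compound 2 and compound 1, so the expectation is loosely held.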

Compound 4, a percentage reported as inhibition, in the whole organism at one dose (the size of the read-out at that dose, not a potency): 42.6%
The estimate for compound 4 lay 41.4 percentage points above the measured number; the whole stated range lies above it.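

In this assay, methyl in place of bromo on an aromatic carbon gives a number 30 percentage points lower from compound 3 to compound 4 (beyond the scatter), so the change cannot be carried from one core to another in this series with its direction assumed, as the two occurrences differ: the same change on two cores in this assay, a number 20 percentage points higher (beyond the scatter) from compound 2 to compound 1 and a number 30 percentage points lower (beyond the scatter) from compound 3 to compound 4, 50 percentage points apart, beyond the scatter of two such steps

The 4-methylphenyl group in place of methyl on an aromatic carbon still gives a number 17.4 percentage points higher from compound 1 to compound 4 (beyond the scatter), so this replacement raises the number with either 4-methylphenyl or 4-bromophenyl as the entering group, though the latter gives the larger a number 47.4 percentage points higher from compound 1 to compound 3 (beyond the scatter). Among the compounds shown here, what this does not show is why the sign reverses: there are only two pairs, each read at a single oral dose, and they do not identify which feature of the core governs the outcome or predict how the change would behave on a third core.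

The compounds shown leave open whether a reversal of this kind also appears with other groups at that place on the aromatic ring, such as chloro, methoxy or an amine. They also leave open whether the pattern persists when a carboxylic acid or a longer chain replaces the methyl on the core of compound 2.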